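Methoxy for Methyl on the Oxindole Ester Series

The source may hold more compounds than are shown below. What is called first, only, known or untested is meant among the compounds shown, and "the series" means these compounds.

Compound 1 `CCOC(=O)/C=C1/C(=O)Nc2ccccc21`: 90.2%
Compound 2 `CN1C(=O)/C(=C/C(=O)OC(C)(C)C)c2ccccc21`: 88.4%
Compound 3 `Cc1ccc2c(c1)/C(=C\C(=O)OC(C)(C)C)C(=O)N2`: 90.3%

In a functional assay on HepG2 cells (Homo sapiens) for inhibition, read by CCK-8 assay, with a stated time of 72 h, tested at 20 uM (a higher number here means more inhibition of growth at the concentration tested, a lower number less inhibition of growth), compound 1 gives 90.2%, compound 2 gives 88.4% and compound 3 gives 90.3%. Compound 3 holds the highest of the three numbers, yet compound 1 lies only a little lower and compound 2 not much further off, both within the scatter, so the three stand together and no order can be read among them.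

Compound 4 `COc1ccc2c(c1)/C(=C\C(=O)OC(C)(C)C)C(=O)N2` differs from compound 3 in one place: methoxy in place of methyl on an aromatic carbon. Among the measured compounds shown here, no step between measured compounds is available to gauge such a change. With all three measured values so close, compound 4 is expected to stay near them, a step of a number 2.3 percentage points lower from compound 3 to compound 4 (within the scatter) that is estimated to be no larger than the scatter. Compound 4 is therefore estimated at 88%, with a range from 75% to 95%.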

Compound 4, percent growth inhibition at one concentration: 90.1%
For compound 4 the middle estimate is 2.1 percentage points below the measured one, and the stated range covers the measured number.
By their numbers in this assay, from the lowest: compounds 2, 4, 1 and 3 (each within the scatter of the next).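

In this assay, the change to methoxy in place of methyl gives the first step measured at this aromatic carbon, a number 0.2 percentage points lower from compound 3 to compound 4 (within the scatter). The earlier compounds shown here offered no such step, and this one shows that the group entering here, with its added hydrogen-bond acceptor by count, leaves the number within the scatter. Nothing measured here accounts for this result.

From the compounds shown here alone, what an amine or a carboxylic acid on this aromatic carbon would give stays open. So does whether a longer chain in place of methoxy would also stay within the scatter of compound 4.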